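Side-chain ethers on a shared core: notes toward compound 4

This account rests on a few compounds, and the source may have more. Where it says the series, first, only, none or still open, it means among the compounds named here.

Measured so far:
Compound 1, `COCCOCCOc1cccc2ccc(N)nc12`, in an assay on cells with melanin-concentrating hormone receptor 1 (Homo sapiens) as the target, read by radioligand binding (a lower number here means a stronger inhibitor, a higher number a weaker inhibitor), gives > 2000 nM, which is a limit of the assay and not a number.
Compound 2, `Nc1ccc2cccc(OCC3CCOC3)c2n1`, gives 115 nM.
Compound 3, `COC(C)(C)CCOc1cccc2ccc(N)nc12`, gives 132 nM.

Compound 2 sits alongside compound 3, the two separated only by a 1.1-fold higher number from compound 2 to compound 3 (0.06 log units; within the scatter), while compound 1 stands apart as a limit (the limit of > 2000 nM in this assay, at which 1 of the 3 values shown sits).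

The next compound, compound 4, `Nc1ccc2cccc(OC3CCCCC3)c2n1`, differs from compound 2 by cyclohexyl in place of (oxolan-3-yl)methyl on an oxygen on an aromatic ring. The side chain thus keeps a saturated ring on the oxygen on the aromatic ring but loses its hydrogen-bond acceptor.

Two measured steps show that leaving the open (2-methoxyethoxy)methyl chain for a ring or a branched group lowers the number strongly: an at least 17-fold lower number from compound 1 to compound 2 (1.24 log units; beyond the scatter) and an at least 15-fold lower number from compound 1 to compound 3 (1.18 log units; beyond the scatter). The step of a 1.1-fold higher number from compound 2 to compound 3 (0.06 log units; within the scatter) shows that oxolan-3-yl and 2-methoxy-2-methylpropyl give numbers within the scatter of each other, so the shape of the group beyond the ring oxygen matters little here. For the measured compounds named here, no measured step removes the acceptor from the side chain, so the change to cyclohexyl is not covered directly; a small rise in the number, possibly within the scatter, is the expectation.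

Compound 4 is therefore estimated at 200 nM, with a range from 60 nM to 700 nM. This estimate means the step of a 1.7-fold higher number from compound 2 to compound 4 (0.24 log units; within the scatter), expected to stay near the scatter.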

Compound 4, half-maximal inhibitory concentration: 361 nM
For compound 4 the middle estimate is 1.8-fold (0.26 log units) below the measured one, and the stated range covers the measured number.
By their numbers in this assay, from the lowest: compounds 2 and 3 (each within the scatter of the next); then compound 4. At a limit, above all of these: compound 1.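

In this assay, the change to cyclohexyl on an oxygen on an aromatic ring gives a 3.1-fold higher number from compound 2 to compound 4 (0.50 log units; beyond the scatter), so this position does respond to the side chain even when the change does not start from the open chain of compound 1. Compound 4 has no hydrogen-bond acceptor in its side chain yet still gives a measured number rather than a limit, which shows that such an acceptor is not needed for a readable value in this assay, although the modest rise leaves room for it to contribute. The same change also replaces the five-membered ring with a six-membered ring of carbon only and sets the ring directly on the oxygen, so the step cannot be assigned to any one of these differences, and nothing available here bears on a cause for it.

Cyclohexylmethyl or oxan-4-yl on the same oxygen would separate the loss of the ring oxygen from the shift in how the ring is attached. On these data alone, whether an amine in the ring, as in piperidin-4-yl, would lower or raise the number remains open.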